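Notes on compound 4 against its parent, compound 1

A few compounds are considered here, and "the series" means these few. Any claim that something is new, unique, unknown or untested is made for them only; others in the source may bear on it.

Measured so far:
compound 1, `COC(=O)c1ccc(OCCCCOc2ccc(C(=O)CC3CCCC3)c(O)c2C)cc1`, gives 12.2% in an assay on HEK293 cells for positive allosteric modulation of metabotropic glutamate receptor 2 (Rattus norvegicus), read by thallium flux, with a stated time of 2.5 min; a higher number here means a larger maximal response, a lower number a smaller maximal response
compound 2, `Cc1c(OCCCCOc2ccc(C(=O)O)cc2F)ccc(C(=O)CC2CCCC2)c1O`, gives 83.8%
compound 3, `COc1ccc(C(=O)O)cc1OCCCCOc1ccc(C(=O)CC2CCCC2)c(O)c1C`, gives 91.8%

Compound 1 stands lowest of the three numbers. The two steps leading away from it, a number 71.6 percentage points higher from compound 1 to compound 2 (beyond the scatter) and a number 79.6 percentage points higher from compound 1 to compound 3 (beyond the scatter), are both large and beyond the scatter, while a number 8 percentage points higher from compound 2 to compound 3 (within the scatter) lies within the scatter. All three steps alter the aryl group on the oxygen on a saturated carbon; none of them touches the ketone side of the shared core.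

Compound 4, `COC(=O)c1ccc(OCCCCOc2ccc(C(=O)CC(C)C)c(O)c2C)cc1`, differs from compound 1 at that untouched end: isopropyl in place of cyclopentyl on a saturated chain carbon bound to a carbonyl carbon. Going by the values given here, no measured step bears on this change. The measured steps speak only to the aryl group on the oxygen, so they give no reading on exchanging the ring for the open chain on the carbon bound to the carbonyl. Among the compounds with values here, the only anchor is compound 1 itself, which gives 12.2% in this assay. With nothing arguing for a shift, the expected step for compound 4 is a number 0.2 percentage points lower from compound 1 to compound 4 (within the scatter), that is, none beyond the scatter. The estimate for compound 4 is 12%, with a range from 0% to 35%.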

Compound 4, largest response reached (reported as percent of maximum), in percent of the reference or control that the assay uses: 16.4%
For compound 4 the middle estimate is 4.4 percentage points below the measured one; low and high end bracket the measured number.
By their numbers in this assay, from the lowest: compounds 1 and 4 (each within the scatter of the next); then compounds 2 and 3 (each within the scatter of the next).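

In this assay, going by these compounds alone, the first change at the ketone side of the shared core, isopropyl in place of cyclopentyl on a saturated chain carbon bound to a carbonyl carbon, gives a number 4.2 percentage points higher from compound 1 to compound 4 (within the scatter) and so does not separate the two compounds. The earlier steps shown here showed large movement only with changes to the aryl group on the oxygen; this one shows that, with the 4-(methoxycarbonyl)phenyl group held fixed, the ring at this place can give way to the open chain, going from 5 heavy atoms to 3, without a step beyond the scatter. Nothing at hand gives a reason for this outcome, or shows whether the ring and the open chain do the same work here.

Going by these compounds, compounds 1 and 4 both sit at the low end of the series, so it remains open whether the same exchange would also leave the number in place on the carboxy-bearing aryl groups, where compound 2 gives 83.8% and compound 3 gives 91.8%. Also open, on these data alone, is how this place responds to a group of another kind, such as a phenyl ring, an amine or a longer chain.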